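The source may hold more compounds than are shown below. What is called first, only, known or untested is meant among the compounds shown, and "the series" means these compounds.

Measured in a functional assay on HCT-116 cells (Homo sapiens) for cytotoxicity, read by sulforhodamine B assay, with a stated time of 24 h; on this read-out lower numbers stand for stronger inhibition and higher numbers for weaker inhibition
- compound 1 `O=C1Nc2ccc(S(=O)(=O)N3CCOCC3)cc2/C1=N/c1ccc(Br)cc1` gives 15300 nM
- compound 2 `Cc1ccc(/N=C2\C(=O)Nc3ccc(S(=O)(=O)N4CCOCC4)cc32)cc1` gives 18900 nM
- compound 3 `O=C1Nc2ccc(S(=O)(=O)N3CCOCC3)cc2/C1=N/NS(=O)(=O)c1ccccc1` gives 13300 nM

Compound 3 cannot be separated from the other two, since all three values lie within the scatter of each other. Next is compound 4 `O=C1Nc2ccc(S(=O)(=O)N3CCOCC3)cc2/C1=N/c1ccc(Cl)cc1`, with 4-chlorophenyl in place of (phenylsulfonyl)amino on a double-bonded nitrogen. The same kind of exchange has been measured twice, as a 1.2-fold lower number from compound 1 to compound 3 (0.06 log units; within the scatter) and as a 1.4-fold lower number from compound 2 to compound 3 (0.15 log units; within the scatter), and the swap of bromo for methyl gave a 1.2-fold higher number from compound 1 to compound 2 (0.09 log units; within the scatter). All three steps stay within the scatter, so no step beyond it is expected in this assay. The expected step is a 1.2-fold higher number from compound 3 to compound 4 (0.08 log units; within the scatter). For compound 4 the estimate is 16000 nM, with an expected range from 10000 nM to 25000 nM.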

Compound 4, half-maximal inhibitory concentration: 24300 nM
The estimate for compound 4 lay 1.5-fold (0.18 log units) below the measured number; the measured number falls inside the stated range.
By their numbers in this assay, from the lowest: compounds 3, 1, 2 and 4 (each within the scatter of the next).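

In this assay, replacing (phenylsulfonyl)amino with 4-chlorophenyl on the double-bonded nitrogen removes the hydrogen-bond donor and acceptors of the leaving group, yet gives a 1.8-fold higher number from compound 3 to compound 4 (0.26 log units; within the scatter). Chloro on the aromatic carbon also reads no differently from methyl or bromo, with a 1.3-fold higher number from compound 2 to compound 4 (0.11 log units; within the scatter) and a 1.6-fold higher number from compound 1 to compound 4 (0.20 log units; within the scatter). No available evidence bears on these results. Still open, from the compounds shown here alone, is whether an amine or a longer alkyl chain in place of 4-chlorophenyl on the double-bonded nitrogen would give a step beyond the scatter in this assay.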